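The compounds below may be only part of what the source reports. "The series", "measured", "known", "first", "only" and "open" are said of these compounds alone.

Among the measured compounds shown here, compound 2 `C[N+]1(CC2CC2)CCc2c(sc(NC(=O)Nc3ccc(Cl)cc3)c2C(N)=O)C1` is one of two compounds measured in a functional assay (strain AB) with Danio rerio as the target, read by microscopy, with a stated time of 1 h; a higher number here means that more compound is needed for the effect, a lower number that less compound is needed. Compound 2 gives 360 nM, the higher of the two numbers. Its nearest neighbour is compound 1 `C[N+]1(CC2CCC2)CCc2c(sc(NC(=O)Nc3ccc(Cl)cc3)c2C(N)=O)C1`, which differs from it in one place only; in this assay compound 1 gives 210 nM. The step of a 1.7-fold higher number from compound 1 to compound 2 (0.23 log units; within the scatter) is the only one measured, and it lies within the scatter.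

Compound 3 `CC[N+]1(C)CCc2c(sc(NC(=O)Nc3ccc(Cl)cc3)c2C(N)=O)C1` goes one step further along the same line: methyl in place of cyclopropyl on a saturated chain carbon bound to an amine nitrogen in a ring. For the measured compounds named here, the only measured step on this chain was small, so a small shift is expected here as well, with the number for this assay thought more likely to rise than to fall, as a 1.4-fold higher number from compound 2 to compound 3 (0.14 log units; within the scatter). Compound 3 is therefore expected to give about 500 nM, with a range from 200 nM to 1300 nM.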

Compound 3, half-maximal effective concentration: 1960 nM
For compound 3 the middle estimate is 3.9-fold (0.59 log units) below the measured one; the measured number lies above the stated range.
By their numbers in this assay, from the lowest: compounds 1 and 2 (each within the scatter of the next); then compound 3.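

In this assay, this position proves far from indifferent to the group it carries: exchanging one small carbon ring for another stayed within the scatter, but methyl in place of cyclopropyl gives a 5.4-fold higher number from compound 2 to compound 3 (0.74 log units; beyond the scatter) and methyl in place of cyclobutyl gives a 9.3-fold higher number from compound 1 to compound 3 (0.97 log units; beyond the scatter) and both steps lie beyond it. Among these three compounds, then, the two that carry a carbon ring on this chain stand together, while compound 3, with ethyl in place of cyclopropylmethyl, needs clearly more compound for the effect. No measurement shown here explains this difference. The compounds cannot tell whether the ring itself matters or only the length of the group, which a straight propyl or butyl chain would help to separate. Going by these compounds, whether a cyclopentyl or phenyl ring would keep the lower numbers also stays open.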